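Phenylsulfonyl in place of pyrrolyl: outlook for compound 3

A few compounds are considered here, and "the series" means these few. Any claim that something is new, unique, unknown or untested is made for them only; others in the source may bear on it.

compound 1 `COc1cc(OC)c2c(=O)cc(C(=O)Nc3ccc(N4CCN(C)CC4)cc3)[nH]c2c1` — > 19800 nM
compound 2 `COc1cc(OC)c2c(=O)cc(C(=O)Nc3ccc(-n4cccc4)cc3)[nH]c2c1` — > 77000 nM

In a functional assay on KOPN-8 cells (Homo sapiens) for antiproliferative activity, with a stated time of 72 h (a lower number here means that less compound is needed, a higher number that more compound is needed for the effect), compound 1 gives only a limit, > 19800 nM. Compound 2 likewise gives only a limit, > 77000 nM. Among the measured compounds shown here, the one measured step, a step that the two limits leave unreadable from compound 1 to compound 2, has no readable size because the limit of > 19800 nM in this assay, at which 1 of the 2 values shown sits, and the limit of > 77000 nM in this assay, at which 1 of the 2 values shown sits, are both limits rather than numbers. Compound 2 therefore stands nowhere definite in this assay: its value is a limit, and the other value shown is a limit too.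

Compound 3 is `COc1cc(OC)c2c(=O)cc(C(=O)Nc3ccc(S(=O)(=O)c4ccccc4)cc3)[nH]c2c1`. It differs from compound 2 by phenylsulfonyl in place of 1H-pyrrol-1-yl on an aromatic carbon. For the measured compounds named here, no measured step bears on this change; the only step in the set is unreadable. Nothing in the data predicts a move beyond the scatter in either direction, and the most probable outcome is that compound 3 again reports a limit. For compound 3 the expected value in this assay is estimated at 30000 nM, within 5000 nM to 100000 nM. This estimate amounts to an expected step of an at least 2.5-fold lower number from compound 2 to compound 3 (0.40 log units; beyond the scatter), which cannot be checked against a limit.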

Compound 3, half-maximal effective concentration: > 70600 nM
Compound 3: a limit, no number; the forecaster's own chance of this, stated with the estimate: 70%; middle value at least 2.3-fold (0.37 log units) from the limit.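

In this assay compound 3 gives only a limit, > 70600 nM. Among the compounds shown here, compound 1, compound 2 and compound 3 all stand as limits, so no step among them can be read. The compounds shown leave open whether 4-methylpiperazin-1-yl, 1H-pyrrol-1-yl and phenylsulfonyl differ at all in this assay, and what number any of them would give.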